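This account rests on a few compounds, and the source may have more. Where it says the series, first, only, none or still open, it means among the compounds named here.

Working notes on a small diaryl ether series tested in a functional assay on HL-60 cells (Homo sapiens) for antiproliferative activity; on this read-out higher numbers stand for weaker inhibition and lower numbers for stronger inhibition.

Compound 1 `COC(=O)c1ccc(Oc2ccc(OC)cc2)c([N+](=O)[O-])c1` is the parent of the set. In this assay compound 1 reaches only the limit > 20000 nM, a boundary of the assay and not a number. Compound 2 `COC(=O)c1ccc(Oc2ccc(OC)c(OC)c2)c([N+](=O)[O-])c1` carries methoxy in place of hydrogen on an aromatic carbon. In this assay compound 2 likewise stops at the limit > 20000 nM. The step that the two limits leave unreadable from compound 1 to compound 2 therefore cannot be sized, because of the limit of > 20000 nM in this assay, at which 3 of the 3 values shown sit.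

Compound 3 `COC(=O)c1ccc(Oc2ccc(OC)cc2)c(N)c1` differs from compound 1 in its core by amino in place of nitro on an aromatic carbon. In this assay compound 3 also gives only the limit > 20000 nM. The step that the two limits leave unreadable from compound 1 to compound 3 is equally unreadable, because of the limit of > 20000 nM in this assay, at which 3 of the 3 values shown sit.

Compound 4 `COC(=O)c1ccc(Oc2ccc(OC)c(OC)c2)c(N)c1` remains to be measured in this assay. It differs from compound 3 by methoxy in place of hydrogen on an aromatic carbon; this is the same change as was made between compound 1 and compound 2, with identical surroundings at the place of change. Since every measured member of the set sits at the same boundary, no trend in either direction is visible among compounds 1, 2 and 3.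

Compound 4 is expected to give about 30000 nM in this assay, within an estimated range from 15000 nM to 80000 nM. The expected step that the limit leaves unreadable from compound 3 to compound 4 is set at no change, resting on the unreadable step that the two limits leave unreadable from compound 1 to compound 2 and on (the limit of > 20000 nM in this assay, at which 3 of the 3 values shown sit). The most probable outcome for compound 4 is another limit rather than a number.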

Compound 4, half-maximal inhibitory concentration: > 20000 nM
Compound 4 gave a limit, no number; the forecaster's own chance of this, stated with the estimate: 85%; the middle value does not contradict the limit.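

No new step can be read for compound 4 against compound 3 or compound 2 in this assay, because all the values are limits of the assay and not numbers: the limit of > 20000 nM in this assay, at which 4 of the 4 values shown sit.

The compounds shown leave open what true values lie behind this limit, and whether methoxy in place of hydrogen or amino in place of nitro changes the read-out at all.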